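Chloro substitution on the methoxyphenyl ring of compound 3

A few compounds are considered here, and "the series" means these few. Any claim that something is new, unique, unknown or untested is made for them only; others in the source may bear on it.

Compound 3 `COc1ccc(C2=C(c3cc(OC)c(OC)c(OC)c3)C(=O)C(O)C2)cc1` gives 6.3 ug/mL in an ADME assay on HEK293 cells (Homo sapiens) for cytotoxicity, read by MTT assay, with a stated time of 72 h (a higher number here means a weaker inhibitor, a lower number a stronger inhibitor), the lowest of the two numbers shown. Compound 1 `COc1ccc(C2=C(c3cc(OC)c(OC)c(OC)c3)C(=O)C(OC(C)=O)C2)cc1Cl` gives 60 ug/mL in this assay. For compound 2 `C=CCOc1cc(C2=C(c3cc(OC)c(OC)c(OC)c3)C(=O)C(O)C2)ccc1OC` the result in this assay is a limit, > 100 ug/mL (the limit of > 100 ug/mL in this assay, at which 1 of the 3 values shown sits). Compound 4 `COc1ccc(C2=C(c3cc(OC)c(OC)c(OC)c3)C(=O)C(O)C2)cc1Cl` differs from compound 3 by chloro in place of hydrogen on an aromatic carbon. Going by the values given here, the only measured step, an at least 15-fold lower number from compound 2 to compound 3 (1.20 log units; beyond the scatter), removed a group from that same aromatic carbon and lowered the number strongly; compound 1, which carries the chloro together with an acetate, also sits well above compound 3. A rise in this assay is therefore expected for compound 4, though smaller than the allyloxy case suggests, estimated as a 4.0-fold higher number from compound 3 to compound 4 (0.60 log units; beyond the scatter). Compound 4 is expected to give 25 ug/mL (8 ug/mL to 80 ug/mL) in this assay.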

Compound 4, half-maximal inhibitory concentration: > 100 ug/mL
Compound 4 was reported as a limit; the forecaster's own chance of this, stated with the estimate: 10%; at least 4.0-fold (0.60 log units) between middle value and limit.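

Exchanging 4-methoxyphenyl for 3-chloro-4-methoxyphenyl gives, as a single change, an at least 15-fold higher number from compound 3 to compound 4 (1.20 log units; beyond the scatter) in this assay, so chloro ortho to a methoxy group raises the number without any acetate present. Exchanging the acetyl on oxygen for hydrogen, with chloro kept, gives an at least 1.6-fold higher number from compound 1 to compound 4 (0.22 log units; that floor lies within the scatter), so the size of this change remains unsettled. The step from compound 2 to compound 4 cannot be read, with both values being limits: the limit of > 100 ug/mL in this assay, at which 2 of the 4 values shown sit.

Going by these compounds, whether fluoro or methyl on this carbon stays close to compound 3 remains open. So does whether the rise follows from any group there.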